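Aryl triazole exchange in the shared core, antiproliferative read-out

The compounds below may be only part of what the source reports. "The series", "measured", "known", "first", "only" and "open" are said of these compounds alone.

Compound 1 `N#CC1=C(N)Oc2c(c3nc4ccccc4nc3c3ccccc23)C12C(=O)N(Cc1cnnn1-c1ccccc1Cl)c1ccccc12` carries a 2-chlorophenyl on the triazole nitrogen. In a functional assay on HepG2 cells (Homo sapiens) for antiproliferative activity, read by MTT assay, with a stated time of 48 h (on this read-out lower numbers stand for stronger inhibition and higher numbers for weaker inhibition), compound 1 returns only a limit, > 50000 nM. Compound 2 `N#CC1=C(N)Oc2c(c3nc4ccccc4nc3c3ccccc23)C12C(=O)N(Cc1cnnn1-c1cccc(Br)c1)c1ccccc12`, the 3-bromophenyl analogue, likewise returns only a limit in this assay, > 50000 nM. The step from 2-chlorophenyl to 3-bromophenyl, a step that the two limits leave unreadable from compound 1 to compound 2, cannot be sized due to the limit of > 50000 nM in this assay, at which 2 of the 2 values shown sit; compound 2 therefore stands nowhere on a numeric scale, only at the limit shared with compound 1.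

Compound 3 `N#CC1=C(N)Oc2c(c3nc4ccccc4nc3c3ccccc23)C12C(=O)N(Cc1cnnn1-c1ccc([N+](=O)[O-])cc1)c1ccccc12` differs from compound 2 in one place: 4-nitrophenyl in place of 3-bromophenyl on an aromatic nitrogen. For the measured compounds named here, no measured step bears on this change, the single available step being unreadable. The expectation is that the shared core again yields no numeric value, so the step from compound 2 to compound 3 is estimated as a number no higher from compound 2 to compound 3 (the limit leaves the size open). Compound 3 is estimated at 50000 nM, within 20000 nM to 150000 nM, most likely reported as a limit.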

Compound 3, half-maximal inhibitory concentration: > 50000 nM
Compound 3 ended at the assay's limit; the forecaster's own chance of this, stated with the estimate: 70%; the middle value sits exactly at the limit.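

The steps among compound 1, compound 2 and compound 3 cannot be read, since each gives only a limit in this assay: the limit of > 50000 nM in this assay, at which 3 of the 3 values shown sit.

On these data alone, whether the 2-chlorophenyl, 3-bromophenyl and 4-nitrophenyl groups differ at all in this assay stays open, as does which change would give a numeric value.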